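Replacing nitro with acetamido on the shared core

The source may report more compounds than this note shows. Statements on the series, on what has been measured and on what is new or still open speak of the compounds shown alone.

Compound 1 `CCOc1ccc(-c2cccc(C(=O)O)c2)cc1` gives > 200000 nM in an assay on COS-7 cells for inhibition of patatin-like phospholipase domain-containing protein 2 (Mus musculus); on this read-out lower numbers stand for stronger inhibition and higher numbers for weaker inhibition; this is a limit of the assay, not a number.
Compound 2 `CCOc1ccc(-c2cccc(C(=O)OCCOC)c2)cc1` gives 70000 nM in this assay.
Compound 3 `CCOc1ccc(-c2cccc([N+](=O)[O-])c2)cc1` gives > 200000 nM in this assay; this too is a limit of the assay.

Compound 3 therefore stands at the weak end of what is shown, sharing its limit with compound 1 (the limit of > 200000 nM in this assay, at which 2 of the 3 values shown sit). Compound 4 `CCOc1ccc(-c2cccc(NC(C)=O)c2)cc1` differs from it by acetamido in place of nitro on an aromatic carbon. Within the data shown here, no measured step involves acetamido. The step of an at least 2.8-fold higher number from compound 2 to compound 3 (0.45 log units; beyond the scatter) shows that nitro gave the weaker of the two. Without a step that reads on acetamido, compound 4 is expected to stay weak, and the estimated step of an at least 1.3-fold lower number from compound 3 to compound 4 (0.12 log units; that floor lies within the scatter) is small. The estimate for compound 4 is 150000 nM, between 40000 nM and 500000 nM.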

Compound 4, half-maximal inhibitory concentration: 200000 nM
The estimate for compound 4 lay 1.3-fold (0.12 log units) below the measured number, and the stated range covers the measured number.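

Acetamido on this aromatic carbon gives a number rather than a limit, and putting it in place of (2-methoxyethoxy)carbonyl modestly weakens inhibition, with a 2.9-fold higher number from compound 2 to compound 4 (0.46 log units; beyond the scatter). Among the groups shown, only the (2-methoxyethoxy)carbonyl ester has a value beyond the scatter of the acetamido result. Acetamido in place of nitro gives a number no higher from compound 3 to compound 4 (the limit leaves the size open), and acetamido in place of carboxy gives a number no higher from compound 1 to compound 4 (the limit leaves the size open). The sizes of these steps to acetamido from nitro and from carboxy cannot be read because those compounds carry limits: the limit of > 200000 nM in this assay, at which 2 of the 4 values shown sit.

Still open, on these data alone, is which part of the ester chain matters. A methyl ester, a longer ether chain or an amine at this position would help to separate those parts.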